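From dimethylamino to nitro on an aromatic carbon

A few compounds are considered here, and "the series" means these few. Any claim that something is new, unique, unknown or untested is made for them only; others in the source may bear on it.

Of the compounds shown here, two so far have numbers in a functional assay on MCF7 cells (Homo sapiens) for antiproliferative activity, read by MTT assay, with stated times of 24 h and 72 h; on this read-out lower numbers stand for stronger inhibition and higher numbers for weaker inhibition. Compound 1 (`COc1cc([C@@H]2[C@H](Oc3ccccc3)C(=O)N2c2cc(OC)c(OC)c(OC)c2)cc(OC)c1OC`) gives 29000 nM here and compound 2 (`COc1cc(N2C(=O)[C@@H](Oc3ccccc3)[C@H]2c2ccc(N(C)C)cc2)cc(OC)c1OC`) gives 31000 nM here. Within the data shown here, that places compound 2 level with its only measured neighbour, since the step is a 1.1-fold higher number from compound 1 to compound 2 (0.03 log units; within the scatter) and nothing more.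

Compound 3 (`COc1cc(N2C(=O)[C@@H](Oc3ccccc3)[C@H]2c2ccc([N+](=O)[O-])cc2)cc(OC)c1OC`) keeps the rest of compound 2 and differs in one group: nitro in place of dimethylamino on an aromatic carbon in short, nitro in place of dimethylamino on an aromatic carbon, para to a large group. Among the measured compounds shown here, only one measured step bears on this, the exchange of 3,4,5-trimethoxyphenyl for 4-(dimethylamino)phenyl, and it stayed within the scatter. For the measured compounds named here, no measured compound carries a nitro, so the data favour no direction. In this assay the expected change is a 1.1-fold lower number from compound 2 to compound 3 (0.04 log units; within the scatter) at most within the scatter. Compound 3 is estimated at 28000 nM with an expected range from 10000 nM to 80000 nM in this assay.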

Compound 3, half-maximal inhibitory concentration: 63000 nM
The estimate for compound 3 lay 2.3-fold (0.35 log units) below the measured number; low and high end bracket the measured number.
By their numbers in this assay, from the lowest: compounds 1 and 2 (each within the scatter of the next); then compound 3.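

In this assay, among these compounds, this place on the ring gives the first change that goes beyond the scatter: the exchange of dimethylamino for nitro is a 2.0-fold higher number from compound 2 to compound 3 (0.31 log units; beyond the scatter) and counts as modest. Exchanging the whole ring gives a similar picture, with 4-nitrophenyl in place of 3,4,5-trimethoxyphenyl being a 2.2-fold higher number from compound 1 to compound 3 (0.34 log units; beyond the scatter) and also modest, whereas 4-(dimethylamino)phenyl and 3,4,5-trimethoxyphenyl had read alike, so the two ring types that matched are not matched by every group at this place. Nothing available explains why nitro gives the weaker inhibition.

As far as these compounds go, how a plain hydrogen, a primary amine or a carboxylic acid would read at this place remains open. Two groups on this ring give a single step, which sets no trend, and a methoxy or a chlorine there could fall on either side of it.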